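The source may report more compounds than this note shows. Statements on the series, on what has been measured and on what is new or still open speak of the compounds shown alone.

Of the compounds shown here, two sharing one core have been measured in a functional assay on XF498 cells (Homo sapiens) for cytotoxicity; on this read-out lower numbers stand for an effect already at smaller amounts and higher numbers for an effect only at larger amounts of compound. Compound 1 `CCCCC/C=C\C[C@@H]1O[C@@H]1/C=C/[C@@H]1C/C=C\CCCC(=O)O1` and compound 2 `CCCCC/C=C\C[C@@H](O)[C@H](O)/C=C/[C@@H]1C/C=C\CCCC(=O)O1` differ only within their side chain. In this assay compound 1 gives 3.6 ug/mL, while compound 2 gives 14.4 ug/mL, the higher of the two numbers, set apart from compound 1 by a gap beyond the usual scatter. Compound 3 `CC/C=C\C/C=C\C[C@@H](O)[C@H](O)/C=C/[C@@H]1C/C=C\CCCC(=O)O1` differs from compound 2 in a single group: but-1-en-1-yl in place of butyl on a saturated chain carbon bound to a double-bonded chain carbon. Going by the values given here, no measured pair shows a change of this kind, so its effect cannot be read off from the data; what is known is only the two numbers already given. The step from compound 2 to compound 3 is therefore expected to be small in this assay, a 1.1-fold lower number from compound 2 to compound 3 (0.04 log units; within the scatter), with no clear direction and likely within the scatter. For compound 3 the estimate in this assay is 13 ug/mL, with a range from 5 ug/mL to 35 ug/mL.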

Compound 3, concentration for half-maximal effect: 4.5 ug/mL
Beside the measured number, compound 3's estimate is 2.9-fold (0.46 log units) above it; the whole stated range lies above it.
By their numbers in this assay, from the lowest: compounds 1 and 3 (each within the scatter of the next); then compound 2.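

Going by these compounds alone, until now, the only change seen in the side chain was the one separating compound 1 from compound 2; this result shows that a different part of that chain also matters in this assay. But-1-en-1-yl in place of butyl on a saturated chain carbon bound to a double-bonded chain carbon gives a 3.2-fold lower number from compound 2 to compound 3 (0.51 log units; beyond the scatter), a modest step, even though both groups have the same number of heavy atoms and the entering group simply adds one double bond. Nothing among the data shown explains this step.

This one pair cannot separate the presence of the double bond from its place in the chain. Also open, going by these compounds, are the effects of a longer chain, a phenyl group or a carboxylic acid here, and whether the same change would give a similar step on compound 1.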